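A few compounds are considered here, and "the series" means these few. Any claim that something is new, unique, unknown or untested is made for them only; others in the source may bear on it.

Measured so far:
compound 1 `ClCc1ccc(Cn2cnc3nc(Cl)nc(Cl)c32)cc1` — 300 nM
compound 2 `ClCc1ccccc1Cn1cnc2ncnc(Cl)c21` — 2040 nM
compound 3 `ClCc1ccccc1Cn1cnc2nc(Cl)nc(Cl)c21` — 14100 nM

The three measured compounds were run in a functional assay on OVCAR-3 cells (Homo sapiens) for cytotoxicity, read by sulforhodamine B assay, with a stated time of 48 h; a lower number here means a stronger inhibitor of growth, a higher number a weaker inhibitor of growth. Compound 1 carries the lowest number of the three, with compound 2 standing a good way higher and compound 3 furthest off. Compound 1 and compound 3 share the same atoms joined differently; the difference between these two is not broken down here.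

Within this set one change is seen once: hydrogen in place of chloro on an aromatic carbon. That change gave a 6.9-fold lower number from compound 3 to compound 2 (0.84 log units; beyond the scatter) in this assay, a modest step.

Compound 4 `ClCc1ccc(Cn2cnc3ncnc(Cl)c32)cc1` has not yet been measured in this assay. It is related to compound 1 by hydrogen in place of chloro on an aromatic carbon, and the place description matches the change from compound 3 to compound 2 word for word, so it is the same change. On that single precedent, a step of similar size is expected, tempered by the fact that compound 1 already gives 300 nM and the earlier step started from a much higher number.

For compound 4 the expected step is a 3.3-fold lower number from compound 1 to compound 4 (0.52 log units; beyond the scatter). Compound 4 is estimated at 90 nM, with a range from 25 nM to 320 nM.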

Compound 4, concentration for 50% growth inhibition: 1810 nM
Compound 4: the middle estimate sits 20-fold (1.30 log units) below what was measured, and the stated range ends below it.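

In this assay, hydrogen in place of chloro on an aromatic carbon between two ring nitrogen atoms gave a 6.0-fold higher number from compound 1 to compound 4 (0.78 log units; beyond the scatter), the opposite direction to the earlier step on the other core. Read across the two cores, which hold the same atoms joined differently, the change does not carry over with its direction intact: the same change on two cores in this assay, a 6.9-fold lower number (0.84 log units; beyond the scatter) from compound 3 to compound 2 and a 6.0-fold higher number (0.78 log units; beyond the scatter) from compound 1 to compound 4, 42-fold (1.62 log units) apart, beyond the scatter of two such steps

This shows that, in these two pairs, the outcome of losing this chloro depends on the core that carries it; it does not show what in the core sets the direction, and two pairs give no rule for a further core.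

Only chloro and hydrogen stand on that carbon in the compounds shown, so it remains open how an amine or a methoxy group there would behave on either core. Also open, on these data alone, is whether the reversal persists with a hydroxymethyl group or a longer chain in place of the chloromethyl group.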